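Side-chain change from compound 2 to compound 3

The compounds below may be only part of what the source reports. "The series", "measured", "known", "first", "only" and "open" are said of these compounds alone.

Of the compounds shown here, two have measured numbers so far, and they share a core. In a physicochemical assay for solubility, in phosphate buffer, with a stated time of 18 h, at pH 7.4 (a higher number here means a more soluble compound, a lower number a less soluble compound), compound 1 (`Nc1nc(-c2ccccn2)nn1-c1ncnc2cc(N3CCNCC3)c([N+](=O)[O-])cc12`) gives 4000 nM as its reading. In the same this assay compound 2 (`COc1cc2ncnc(-n3nc(-c4ccccn4)nc3N)c2cc1OCCCN(C)C`) gives 53000 nM as its reading, the higher of the two numbers, and the gap to compound 1 lies beyond the scatter. These two compounds differ in more than one place, so their gap cannot be assigned to a single group.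

Compound 3 (`COc1cc2ncnc(-n3nc(-c4ccccn4)nc3N)c2cc1OCCCNC(=O)OC(C)(C)C`) is still unmeasured. Its difference from compound 2 is (tert-butoxycarbonyl)amino in place of dimethylamino on a saturated chain carbon, three bonds along the chain from an oxygen on an aromatic ring in count, with (tert-butoxycarbonyl)amino in place of dimethylamino on a saturated chain carbon, three bonds along the chain from an oxygen on an aromatic ring. Going by the values given here, no measured pair shows this change directly, so the expectation is a judgement. A fall beyond the scatter is expected in this assay for this change. The estimated step is an 11-fold lower number from compound 2 to compound 3 (1.03 log units; beyond the scatter) in size. For compound 3 the estimate is 5000 nM as the middle value, with an expected range from 1200 nM to 20000 nM as its ends.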

Compound 3, solubility: 2000 nM
Beside the measured number, compound 3's estimate is 2.5-fold (0.40 log units) above it; low and high end bracket the measured number.
By their numbers in this assay, from the lowest: compounds 3 and 1 (each within the scatter of the next); then compound 2.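

Working notes on the side chain: in this assay the change to (tert-butoxycarbonyl)amino in place of dimethylamino, on a saturated chain carbon, three bonds along the chain from an oxygen on an aromatic ring, gives a 27-fold lower number from compound 2 to compound 3 (1.42 log units; beyond the scatter) and is the only single-place step available in the series. The reading at this chain end therefore depends strongly on the group it carries, which the earlier pair could not show, as compound 1 and compound 2 differ in more than one place. No measurement shown here accounts for the size of the step.

Going by these compounds alone, the single step exchanges the whole terminal group at once, so it remains open whether a plain primary amine or an acetamide at the same chain end would read nearer to compound 2 or to compound 3, and so which part of the (tert-butoxycarbonyl)amino group goes with the fall. Also open, going by these compounds, is whether the same exchange on a longer chain would give a step of similar size.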